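The source may report more compounds than this note shows. Statements on the series, on what has been measured and on what is new or still open speak of the compounds shown alone.

Measured compounds:
Compound 1, `COc1ncc(-c2ccc3nc(NC(=O)NC4CC4)sc3c2)cc1NS(=O)(=O)c1ccc(F)cc1`, in a functional assay on HCT-116 cells (Homo sapiens) for antiproliferative activity, read by MTT assay, with a stated time of 72 h (a lower number here means a stronger inhibitor, a higher number a weaker inhibitor), compound 1 gives 470 nM.
Compound 2, `O=C(Nc1nc2ccc(-c3cnc(Cl)c(NS(=O)(=O)c4ccc(F)cc4)c3)cc2s1)NC1CC1`, in this assay compound 2 gives 1750 nM.

Among the compounds with values here, compound 2 stands at the higher of the two numbers measured; its nearest neighbour is compound 1, and the only measured step, a 3.7-fold higher number from compound 1 to compound 2 (0.57 log units; beyond the scatter), is the exchange of chloro for methoxy on an aromatic carbon.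

Compound 3, `O=S(=O)(Nc1cc(-c2ccc3nc(NC4CC4)sc3c2)cnc1Cl)c1ccc(F)cc1`, keeps the chloro of compound 2 and differs from it at one place:
cyclopropyl in place of cyclopropylcarbamoyl on a nitrogen on an aromatic ring
Within the data shown here, no measured step touches this part of the structure; the one step available concerns a different position, so it gives no direct guide to the size or direction of the change from cyclopropylcarbamoyl to cyclopropyl. With no comparison of this kind in the series, the expectation is loosely held. The working estimate for compound 3 is a higher number in this assay than for compound 2, the expected step being a 2.9-fold higher number from compound 2 to compound 3 (0.46 log units; beyond the scatter), with a wide range. Compound 3 is therefore estimated at 5000 nM, expected between 1200 nM and 25000 nM.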

Compound 3, half-maximal inhibitory concentration: 5750 nM
Estimate against measurement, compound 3: 1.2-fold (0.06 log units) below; measured number inside the range.
By their numbers in this assay, from the lowest: compound 1; then compound 2; then compound 3.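

In this assay, within the data shown here, cyclopropyl in place of cyclopropylcarbamoyl on a nitrogen on an aromatic ring comes with a 3.3-fold higher number from compound 2 to compound 3 (0.52 log units; beyond the scatter), the first reading at this position, and it shows that the number also depends on what sits on this nitrogen, not only on the chloro or methoxy group changed in the earlier step. Cyclopropyl is present on both sides of the change, so the ring alone does not hold the number where it stands in compound 2; the carbonyl and the amide hydrogen of the leaving group are what the two structures differ by, yet compound 3 still gives 5750 nM, a measured number rather than a limit. No measurement to hand explains this step.

As far as these compounds go, the step has been read only with chloro on the aromatic carbon, so whether it keeps its size and direction with the methoxy group of compound 1 remains open. Also open, from the compounds shown here alone, is how a free amine, an acetyl group or a longer chain on this nitrogen would read, and so whether the carbonyl or the length of the group matters more.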